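A few compounds are considered here, and "the series" means these few. Any claim that something is new, unique, unknown or untested is made for them only; others in the source may bear on it.

In a functional assay on L1210 cells (Mus musculus) for inhibition (on this read-out higher numbers stand for weaker inhibition and lower numbers for stronger inhibition), three compounds have been examined, and none of them inhibits strongly. Compound 1 `CC(C)C(NC(=O)NO)C(=O)NC1CCCCC1` reaches only a limit of the assay, > 100000 nM. Compound 3 `CCC(C)C1NC(=O)N(Cc2ccccc2)C1=O` likewise returns a limit, > 200000 nM. Going by the values given here, compound 2 `CCC(C)C(NC(=O)n1nnc2ccccc21)C(=O)NC1CCCCC1` is the one compound with a measured number: in this assay compound 2 gives 109000 nM. Where compound 2 stands is therefore simple to say: it holds the only number shown, while the other two values are limits, one being the limit of > 100000 nM in this assay, at which 1 of the 3 values shown sits, and the other (the limit of > 200000 nM in this assay, at which 1 of the 3 values shown sits).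

Compound 4 `CCC(C)C(NC(=O)n1nnc2ccccc21)C(=O)NC1CCCC1` has not yet been measured in this assay. It differs from compound 2 in one place: cyclopentyl in place of cyclohexyl on an amide-type nitrogen whose other neighbours are a carbonyl carbon, or, cut one bond further out, cyclohexylamino to cyclopentylamino. Among the compounds with values here, no measured step of this kind exists among the three compounds, so the expectation can rest only on the weak inhibition that compound 2 shows at 109000 nM and on the change itself. In this assay the step of a 1.1-fold higher number from compound 2 to compound 4 (0.04 log units; within the scatter) is expected, in either direction, not beyond the usual scatter. Compound 4 is accordingly estimated at 120000 nM, with a range from 50000 nM to 300000 nM.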

Compound 4, half-maximal inhibitory concentration: 102000 nM
Estimate against measurement, compound 4: 1.2-fold (0.07 log units) above; the measured number falls inside the stated range.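

In this assay, going by these compounds alone, this pair gives the first measured step at this place, on an amide-type nitrogen whose other neighbours are a carbonyl carbon: a 1.1-fold lower number from compound 2 to compound 4 (0.03 log units; within the scatter). Cyclopentyl in place of cyclohexyl thus does not separate the two compounds, which differ nowhere else: compound 4 gives 102000 nM and compound 2 gives 109000 nM, so both remain weak inhibitors, and the ring with one carbon fewer has no effect that can be read on this read-out in this pair. Nothing among the data offers a cause for this result, and the limits reached by other compounds do not bear on it.

The compounds shown leave open whether a carboxylic acid, an amine or a longer chain on this nitrogen would give a number that differs from that of compound 2 beyond the scatter. They also leave open how much the other places on the shared core contribute to the weak inhibition, as this single step speaks only for cyclohexyl and cyclopentyl at this one place.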